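Adding a second methoxy to compound 3

The source may report more compounds than this note shows. Statements on the series, on what has been measured and on what is new or still open speak of the compounds shown alone.

Three compounds share one core and differ in the group on an aromatic nitrogen, and all were tested in a functional assay on HCT-15 cells (Homo sapiens) for antiproliferative activity, read by MTT assay, with a stated time of 72 h; on this read-out lower numbers stand for stronger inhibition and higher numbers for weaker inhibition. Compound 1 `CCn1ccnc1-c1cc(OC)c(OC)c(OC)c1`, with ethyl on that nitrogen, gives > 100000 nM, which is a limit of the assay and not a number. Compound 2 `COc1cc(-c2nccn2-c2cccc(C)c2)cc(OC)c1OC`, with 3-methylphenyl, gives 1600 nM. Compound 3 `COc1cccc(-n2ccnc2-c2cc(OC)c(OC)c(OC)c2)c1`, with 3-methoxyphenyl, gives 17100 nM, the higher of the two actual numbers in this set.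

Compound 4 `COc1cc(OC)cc(-n2ccnc2-c2cc(OC)c(OC)c(OC)c2)c1` keeps all of compound 3 and makes one change: methoxy in place of hydrogen on an aromatic carbon. This is methoxy in place of hydrogen on an aromatic carbon, meta to a large group and meta to a methoxy group.

Putting a ring on that nitrogen lowered the number, with an at least 62-fold lower number from compound 1 to compound 2 (1.79 log units; beyond the scatter) and an at least 5.8-fold lower number from compound 1 to compound 3 (0.76 log units; beyond the scatter). These steps say little about a further group on the ring. The closest guide is an 11-fold higher number from compound 2 to compound 3 (1.03 log units; beyond the scatter), which shows that methoxy can raise the number at a nearby stage. However, in that step methoxy replaced methyl, whereas here it replaces hydrogen, and no measured step adds a second group to this ring. The expected change is therefore small, leaning slightly upward, and is estimated as a 1.2-fold higher number from compound 3 to compound 4 (0.07 log units; within the scatter). Compound 4 is expected to give about 20000 nM, with an estimated range of 5000 nM to 80000 nM.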

Compound 4, half-maximal inhibitory concentration: > 100000 nM
Compound 4 was reported as a limit (the forecaster's own chance of this, stated with the estimate: 15%); middle value at least 5.0-fold (0.69 log units) from the limit.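

At this position, an aromatic carbon meta to a large group and meta to a methoxy group, adding methoxy in place of hydrogen clearly weakens the result: in this assay there is an at least 5.8-fold higher number from compound 3 to compound 4 (0.76 log units; beyond the scatter). The earlier steps shown here only exchanged one group for another, whereas this step adds a second group to the ring of compound 3, and its direction matches that of the exchange of methyl for methoxy, which gave an 11-fold higher number from compound 2 to compound 3 (1.03 log units; beyond the scatter). Compound 4 gives a limit of the assay and not a number, so this step shows only the smallest possible size of the change: the limit of > 100000 nM in this assay, at which 2 of the 4 values shown sit.

The compounds shown leave open whether this loss belongs to methoxy in particular or would follow any group at this carbon, a question that fluorine, a hydroxyl or an amine in the same place could help to settle. They also leave open how far the true number for compound 4 lies past the limit, and they give no reason for the change.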